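This account rests on a few compounds, and the source may have more. Where it says the series, first, only, none or still open, it means among the compounds named here.

In an assay on isolated protein for inhibition of tyrosine-protein kinase Mer (Homo sapiens), read by LC-MS (on this read-out higher numbers stand for weaker inhibition and lower numbers for stronger inhibition), the measured compounds stand as follows:

compound 1 `CN(Cc1ccc2nccn2c1)c1nnc(-c2ccccc2)o1`: 15800 nM
compound 2 `CN(Cc1ccc2nccn2c1)c1nnc(-c2ccc(-c3ccccc3F)cc2)o1`: 15.9 nM
compound 3 `COc1ccccc1-c1ccc(-c2nnc(N(C)Cc3ccc4nccn4c3)o2)cc1`: 31.6 nM

Compound 3 holds the second highest of the three numbers. Its nearest neighbour is compound 2, with a 2.0-fold higher number from compound 2 to compound 3 (0.30 log units; within the scatter); its furthest is compound 1, with a 500-fold lower number from compound 1 to compound 3 (2.70 log units; beyond the scatter).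

Compound 4 `Cc1nn(C)c(C)c1-c1ccc(-c2nnc(N(C)Cc3ccc4nccn4c3)o2)cc1` differs from compound 3 by 1,3,5-trimethyl-1H-pyrazol-4-yl in place of 2-methoxyphenyl on an aromatic carbon. Among the measured compounds shown here, the steps that bear on this are a 990-fold lower number from compound 1 to compound 2 (3.00 log units; beyond the scatter) and a 500-fold lower number from compound 1 to compound 3 (2.70 log units; beyond the scatter), which show that a group at this position accounts for nearly all of the gain over compound 1, while a 2.0-fold higher number from compound 2 to compound 3 (0.30 log units; within the scatter) shows the two six-membered variants do not separate beyond the scatter. For the measured compounds named here, no measured step covers a five-membered group here. A small step, a 1.9-fold higher number from compound 3 to compound 4 (0.28 log units; within the scatter), is expected for compound 4, at most just beyond the scatter. Compound 4 is estimated at 60 nM, between 15 nM and 250 nM.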

Compound 4, half-maximal inhibitory concentration: 31.6 nM
For compound 4 the middle estimate is 1.9-fold (0.28 log units) above the measured one; low and high end bracket the measured number.
By their numbers in this assay, from the lowest: compounds 2, 3 and 4 (each within the scatter of the next); then compound 1.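

The 1,3,5-trimethyl-1H-pyrazol-4-yl group, with its five-membered aromatic ring, does not separate from 2-methoxyphenyl (no change at the digits printed from compound 3 to compound 4 (within the scatter)) or from 2-fluorophenyl (a 2.0-fold higher number from compound 2 to compound 4 (0.30 log units; within the scatter)). The gain over hydrogen (a 500-fold lower number from compound 1 to compound 4 (2.70 log units; beyond the scatter)) therefore does not require a six-membered aromatic ring of carbon only at this place, at least among these three groups. Nothing available explains this equivalence.

From the compounds shown here alone, whether a single methyl, an amine or a carboxylic acid at this place would keep the gain remains open. So does whether an unsubstituted pyrazole ring would match the trimethyl version.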